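A Chlorophenyl Swap on Compound 2

The compounds below may be only part of what the source reports. "The series", "measured", "known", "first", "only" and "open" are said of these compounds alone.

In a functional assay on DWD cells (Homo sapiens) for inhibition, read by sulforhodamine B assay (a higher number here means a weaker inhibitor of growth, a lower number a stronger inhibitor of growth), compound 1 (`Clc1cccc(-c2ccc(-c3ccc(-c4nc5ccccc5[nH]4)cc3)cc2)c1`) gives 100000 nM while compound 2 (`Oc1ccc(-c2ccc(-c3ccc(-c4nc5c(O)cccc5[nH]4)cc3)cc2)cc1`) gives 2700 nM and so holds the lower of the two numbers, with a gap beyond the usual scatter. Compound 3 (`Oc1cccc2[nH]c(-c3ccc(-c4ccc(-c5cccc(Cl)c5)cc4)cc3)nc12`) differs from compound 2 in one place: 3-chlorophenyl in place of 4-hydroxyphenyl on an aromatic carbon. For the measured compounds named here, no measured pair shows this swap on its own. Going by the values given here, the only guide is compound 1, which also carries a 3-chlorophenyl and gives 100000 nM as the weaker inhibitor of the two. The expected change is a 4.4-fold higher number from compound 2 to compound 3 (0.65 log units; beyond the scatter) toward a higher number, which means weaker inhibition, and it would lie beyond the scatter. Compound 3 is estimated at 12000 nM (expected range 3000 nM to 45000 nM).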

Compound 3, concentration for 50% growth inhibition: 2100 nM
For compound 3 the middle estimate is 5.7-fold (0.76 log units) above the measured one, outside the stated range (below it).
By their numbers in this assay, from the lowest: compounds 3 and 2 (each within the scatter of the next); then compound 1.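

Putting 3-chlorophenyl in place of 4-hydroxyphenyl gives a 1.3-fold lower number from compound 2 to compound 3 (0.11 log units; within the scatter) in this assay and so leaves the number within the scatter, even though the entering group has 0 hydrogen-bond donors and the leaving group has 1. Hydroxy in place of hydrogen on an aromatic carbon gives a 48-fold lower number from compound 1 to compound 3 (1.68 log units; beyond the scatter) with the 3-chlorophenyl kept, a large step. Compound 1 and compound 2 differ in two places, so they could not separate these changes, whereas these two steps show that only the hydroxy change moves the number beyond the scatter.

Going by these compounds, whether this position would accept an aminophenyl or a carboxylic acid on the ring as well remains open. So does whether a methoxy group could stand in for the hydroxy on the core. Nothing shown here explains either step.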